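The source may report more compounds than this note shows. Statements on the series, on what has been measured and on what is new or still open speak of the compounds shown alone.

Compound 1, `COC(=O)C1(S(=O)(=O)c2ccc(Oc3ccc(OC(F)(F)F)cc3)cc2)CCC2(CCNCC2)C1`, has no exact number in a functional assay on blood (Homo sapiens), with a stated time of 60 min, in the presence of a further agent that is not named here; on this read-out lower numbers stand for an effect already at smaller amounts and higher numbers for an effect only at larger amounts of compound. There compound 1 gives > 15000 nM, which is a limit of the assay and not a measured number. Its close relative, compound 2, `NC(=O)C1(S(=O)(=O)c2ccc(Oc3ccc(OC(F)(F)F)cc3)cc2)CCC2(CCNCC2)C1`, does give a number in this assay, and compound 2 reads 3700 nM.

The next structure is compound 3, `O=C(Nc1nccs1)C1(S(=O)(=O)c2ccc(Oc3ccc(OC(F)(F)F)cc3)cc2)CCC2(CCNCC2)C1`, made from compound 1 by one change at the methoxycarbonyl group: (1,3-thiazol-2-yl)amino in place of methoxy on a carbonyl carbon.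

Among the compounds with values here, only one measured step bears on this change. It also replaces methoxy with a nitrogen group on that carbonyl carbon, in that case amino, and it gave an at least 4.0-fold lower number from compound 1 to compound 2 (0.60 log units; beyond the scatter). That single step starts from a limit, and it says nothing directly about the added thiazole ring, so any forecast stays loose. A move to a lower number of similar size is the most reasonable expectation, though compound 3 could still prove as weak as compound 1.

The expected change is an at least 6.0-fold lower number from compound 1 to compound 3 (0.77 log units; beyond the scatter). For compound 3 the estimated value is 2500 nM, with an expected range from 400 nM to 15000 nM.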

Compound 3, half-maximal effective concentration: > 15000 nM
Compound 3 was reported as a limit; the forecaster's own chance of this, stated with the estimate: 25%; middle value at least 6.0-fold (0.77 log units) from the limit.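

The new step shows that the thiazole ring does not carry over the gain seen with the plain amide: in this assay there is an at least 4.0-fold higher number from compound 2 to compound 3 (0.60 log units; beyond the scatter), and the reading for compound 3 is a limit and not a number. A nitrogen group on this carbonyl carbon is therefore not enough on its own to give a measurable effect, since the amino group of compound 2 gives a number while the (1,3-thiazol-2-yl)amino group of compound 3 does not. The step between compound 1 and compound 3 cannot be read, so neither compound can be placed ahead of the other, because both stop at the same limit: the limit of > 15000 nM in this assay, at which 2 of the 3 values shown sit.

Going by these compounds, it remains open whether the loss belongs to the thiazole ring itself or to any added group on the amide-type nitrogen, which a small methylamino group or a simple phenylamino group on the same carbonyl carbon would help to separate. Also open, on these data alone, is whether a carboxylic acid at this place, or a group with no carbonyl at all such as an aminomethyl group, would give a lower number than compound 2 does.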